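Swapping One Aromatic Group for Another

The source may report more compounds than this note shows. Statements on the series, on what has been measured and on what is new or still open speak of the compounds shown alone.

Compound 1 `N#Cc1cc(-c2nc(C(c3ccc(F)cc3)c3ccc(F)cc3)sc2CC(=O)O)ccc1F` was tested in an in vitro functional assay on HEK285-7 cells for antagonist activity at prostaglandin D2 receptor 2 (Homo sapiens), read by BRET and beta-arrestin recruitment (a higher number here means a larger maximal response, a lower number a smaller maximal response), where compound 1 gives 80%. A related compound, compound 2 `COc1ccc(OC)c(-c2nc(C(c3ccccc3)c3ccccc3)sc2CC(=O)O)c1`, carries a different aromatic group on the shared core, and in this assay compound 2 gives 80%. On these numbers compound 1 stands level with compound 2, its nearest neighbour, with no difference at the digits shown and nothing beyond the usual scatter between them. The unmeasured compound 3 `O=C(O)Cc1sc(C(c2ccc(F)cc2)c2ccc(F)cc2)nc1-c1cc(F)nc(F)c1` differs from compound 1 in a single place: 2,6-difluoropyridin-4-yl in place of 3-cyano-4-fluorophenyl on an aromatic carbon. Since two rather different aromatic groups already give the same maximal response, no change beyond the usual scatter is expected from this exchange. The step of no change at the digits printed from compound 1 to compound 3 (within the scatter) is expected to be small. Compound 3 is therefore estimated to reach 80% in this assay, with a range from 65% to 95%.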

Compound 3, largest response reached (reported as efficacy), in percent of the reference or control that the assay uses: 80%
Estimate against measurement, compound 3: no gap at the digits printed; measured number inside the range.
By their numbers in this assay, from the lowest: compounds 1, 2 and 3 (each within the scatter of the next).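

Replacing 3-cyano-4-fluorophenyl with 2,6-difluoropyridin-4-yl on the aromatic carbon next to the ring nitrogen gives no change at the digits printed from compound 1 to compound 3 (within the scatter) in this assay. Going by these compounds alone, compound 1 and compound 2 differ in more than one place, whereas this pair gives the first reading of this position alone. With the rest of the molecule unchanged, a ring of carbon only that carries a nitrile can give way to a ring with a hetero atom and no triple bond, and the maximal response shows no shift beyond the scatter. Nothing shown here explains why the response holds across this exchange.

All the groups shown at this position are six-membered aromatic rings. As far as these compounds go, whether a thiophene ring, a morpholine or a simple aminomethyl group would give the same maximal response remains open.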